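Fluoro on the trifluoromethyl compound: half-life working notes

The compounds below may be only part of what the source reports. "The series", "measured", "known", "first", "only" and "open" are said of these compounds alone.

Measured in an ADME assay on the whole organism for metabolic stability, with Rattus norvegicus as the target, read by LC-MS (on this read-out higher numbers stand for a longer-lived compound and lower numbers for a shorter-lived compound), so far:
- compound 1 `Cc1cc(C(=O)N[C@H]2CCCCC/C=C\[C@@H]3C[C@@]3(C(=O)NS(=O)(=O)C3CC3)NC(=O)[C@@H]3C[C@@H](Oc4nc5ccccc5nc4C)CN3C2=O)no1` gives 2.4 h
- compound 2 `Cc1cc(C(=O)N[C@H]2CCCCC/C=C\[C@@H]3C[C@@]3(C(=O)NS(=O)(=O)C3CC3)NC(=O)[C@@H]3C[C@@H](Oc4nc5ccccc5nc4C(F)(F)F)CN3C2=O)no1` gives 1.2 h

Not yet measured: compound 3 `Cc1cc(C(=O)N[C@H]2CCCCC/C=C\[C@@H]3C[C@@]3(C(=O)NS(=O)(=O)C3CC3)NC(=O)[C@@H]3C[C@@H](Oc4nc5cc(F)ccc5nc4C(F)(F)F)CN3C2=O)no1`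

Compound 2, at 1.2 h, cannot be separated from compound 1 on these numbers, since the two lie within the scatter of each other. Compound 3 keeps everything in compound 2 except for one place, with fluoro in place of hydrogen on an aromatic carbon. Among the compounds with values here, no measured step makes this change, so there is no direct precedent for it. Within the data shown here, the nearest evidence is the single step available, trifluoromethyl in place of methyl on an aromatic carbon, which is a 2.0-fold lower number from compound 1 to compound 2 (0.30 log units; within the scatter). That is a different change at a different place, and it shows only that one substitution on the shared core has not yet moved this assay beyond the scatter. The same is expected here, in neither direction, and the estimated step is a 1.1-fold higher number from compound 2 to compound 3 (0.03 log units; within the scatter). For compound 3 the expected half-life is 1.3 h, with an estimated range of 0.6 h to 2.6 h.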

Compound 3, half-life: 2.1 h
Compound 3: the middle estimate sits 1.6-fold (0.21 log units) below what was measured; the range from low to high includes it.
By their numbers in this assay, from the lowest: compounds 2, 3 and 1 (each within the scatter of the next).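

In this assay, within the data shown here, the first direct reading of fluoro in place of hydrogen on an aromatic carbon is a 1.8-fold higher number from compound 2 to compound 3 (0.24 log units; within the scatter) and so lies within the scatter. With trifluoromethyl in place, the position on the six-membered aromatic ring of carbon only, meta to a fused ring and para to a fused ring, therefore accepts fluoro with no half-life difference that these numbers can separate from hydrogen, something the earlier step at the trifluoromethyl place could not show. No measurement bears on why the reading falls where it does.

As far as these compounds go, it remains open whether a larger group at this same position, such as chloro, methoxy or an amine, would take the half-life beyond the scatter, since a single fluoro defines neither the size nor the kind of group the position will accept. Among these compounds, also open is whether fluoro at this position gives a similar step with methyl in place of trifluoromethyl, as the only reading of this change comes from the trifluoromethyl compound.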